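Piperidine amide series: hydroxy to difluoromethyl step

This account rests on a few compounds, and the source may have more. Where it says the series, first, only, none or still open, it means among the compounds named here.

Measured so far:
compound 1 `CCN(CC)S(=O)(=O)c1ccc(S(=O)(=O)N2CCC[C@@H](C(=O)N3CCC(O)CC3)C2)cc1`: 870 nM
compound 2 `CN(C)S(=O)(=O)c1ccc(S(=O)(=O)N2CCC[C@@H](C(=O)N3CCC(F)(F)CC3)C2)cc1`: 118 nM

In a functional assay on MIA PaCa-2 cells (Homo sapiens) for inhibition, read by MTT assay, with a stated time of 7 days (a higher number here means a weaker inhibitor, a lower number a stronger inhibitor), compound 1 gives 870 nM, the highest of the two numbers. Among the measured compounds shown here, compound 2 gives 118 nM in this assay, a lower number beyond the scatter; compound 2 differs from compound 1 in two places, so no single step is tallied for that pair.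

Compound 3 `CCN(CC)S(=O)(=O)c1ccc(S(=O)(=O)N2CCC[C@@H](C(=O)N3CCC(C(F)F)CC3)C2)cc1` differs from compound 1 in one place: difluoromethyl in place of hydroxy on a saturated ring carbon. For the measured compounds named here, no measured pair isolates this change. Compound 2, which also carries fluorine on the same ring, shows the lower number, so a modest downward step is expected, a 2.5-fold lower number from compound 1 to compound 3 (0.40 log units; beyond the scatter). Compound 3 is therefore estimated at 350 nM, with a range of 120 nM to 900 nM.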

Compound 3, half-maximal inhibitory concentration: 420 nM
Beside the measured number, compound 3's estimate is 1.2-fold (0.08 log units) below it, within the range that was stated.
By their numbers in this assay, from the lowest: compound 2; then compound 3; then compound 1.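

In this assay, among the compounds shown here, difluoromethyl in place of hydroxy on the saturated ring carbon is a modest step, a 2.1-fold lower number from compound 1 to compound 3 (0.32 log units; beyond the scatter), and it is the only single-place reading at this position. The hydrogen-bond donor and acceptor of the hydroxy are therefore not required for inhibition in compound 3. Nothing available accounts for the step.

On these data alone, whether an amine, a carboxylic acid or a methoxy group on the same ring carbon would move the number stays open. So does whether the step carries over to cores other than that of compound 1.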